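Shortening the Side Chain of Compound 1

The source may hold more compounds than are shown below. What is called first, only, known or untested is meant among the compounds shown, and "the series" means these compounds.

Of the compounds shown here, two that share one core have been measured in an assay on isolated protein for inhibition of retinal dehydrogenase 2 (Homo sapiens); a higher number here means a weaker inhibitor, a lower number a stronger inhibitor. Compound 1 `CCC(Sc1nc2c(cnn2C)c(=O)n1-c1ccccc1)c1ccccc1` gives 179 nM in this assay, the lowest of the two numbers shown. Among the compounds with values here, compound 2 `Cn1ncc2c(=O)n(-c3ccccc3)c(/C=C/c3cccc(F)c3)nc21` gives 440 nM in this assay, and its gap to compound 1 lies beyond the usual scatter; the two differ in the whole group attached to the core, so no single-point step connects them. Compound 3 `CC(Sc1nc2c(cnn2C)c(=O)n1-c1ccccc1)c1ccccc1` has not yet been measured. It differs from compound 1 in one place: hydrogen in place of methyl on a saturated chain carbon, two bonds along the chain from an aromatic carbon and a sulfur. Taking the methyl off the chain is a small alteration, and no measured pair shows what such a trim does here. Compound 3 is therefore expected to stay close to compound 1, with a step of a 1.4-fold higher number from compound 1 to compound 3 (0.15 log units; within the scatter) that may well fall within the scatter. The estimate for compound 3 in this assay is 250 nM, in a range from 90 nM to 700 nM.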

Compound 3, half-maximal inhibitory concentration: 110 nM
For compound 3 the middle estimate is 2.3-fold (0.36 log units) above the measured one; measured number inside the range.
By their numbers in this assay, from the lowest: compounds 3 and 1 (each within the scatter of the next); then compound 2.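

In this assay the change from ethyl to methyl gives a 1.6-fold lower number from compound 1 to compound 3 (0.21 log units; within the scatter), a step within the scatter, so compound 3 and compound 1 cannot be told apart by this measure. This is the first pair shown that differs in one place only, and it indicates that, on this saturated chain carbon, a 1-phenylethyl group serves about as well as a 1-phenylpropyl group. Nothing available explains why the two numbers stay so close.

Still open, from the compounds shown here alone, is whether this position would also accept a longer chain such as propyl, or a chain ending in an amine or a carboxylic acid. It is also unknown what would happen if the remaining methyl gave way to hydrogen, since one trim within the scatter does not show how far the chain can be changed.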